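The source may report more compounds than this note shows. Statements on the series, on what has been measured and on what is new or still open speak of the compounds shown alone.

Of the compounds shown here, three built on a shared core have been tested in a functional assay on MDA-MB-231 cells (Homo sapiens) for cytotoxicity, read by MTT assay, with a stated time of 72 h; on this read-out higher numbers stand for weaker inhibition and lower numbers for stronger inhibition. Compound 1 `COc1ccc(-c2ccc(C)n2-c2ccc(-c3nc4ccccc4s3)cc2)cc1` gives 14800 nM. Compound 2 `COc1cc(-c2ccc(C)n2-c2ccc(-c3nc4ccccc4s3)cc2)cc(OC)c1OC`, which carries additional methoxy groups on its outer ring, gives 16000 nM. Compound 3 `COc1cc2nc(-c3ccc(-n4c(C)ccc4-c4ccc(C)cc4)cc3)sc2c(OC)c1OC`, which instead carries methoxy groups on its fused ring system and a methyl on the outer ring, gives 12300 nM in this assay. The number for compound 3 is the lowest of the three, but its nearest neighbour is compound 1 and its furthest is compound 2, and both of those gaps fall inside the usual scatter of repeated measurements, so the three compounds cannot be told apart on these data.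

Compound 4 `COc1ccc(-c2ccc(C)n2-c2ccc(-c3nc4cc(OC)c(OC)c(OC)c4s3)cc2)cc1` has not yet been measured. It differs from compound 3 in a single place: methoxy in place of methyl on an aromatic carbon, a methoxy in place of methyl on an aromatic carbon, para to a large group. Within the data shown here, no pair of measured compounds differs in exactly this way, so there is no measured step to lean on. What the measured compounds do show is that moving methoxy groups around the structure has left all three numbers within the scatter of one another. On that basis the step is expected to be a 1.1-fold higher number from compound 3 to compound 4 (0.02 log units; within the scatter), nothing beyond the scatter. Compound 4 is therefore expected to give 13000 nM in this assay, with a likely range from 6000 nM to 28000 nM.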

Compound 4, half-maximal inhibitory concentration: 12500 nM
For compound 4 the middle estimate is 1.0-fold (0.02 log units) above the measured one; the measured number falls inside the stated range.
By their numbers in this assay, from the lowest: compounds 3, 4, 1 and 2 (each within the scatter of the next).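

Among these compounds, this is the first pair in the set that differs in one place only, so a single change can now be read on its own, where the earlier compounds differed in more than one place. Going from 4-methylphenyl to 4-methoxyphenyl in this assay gives a 1.0-fold higher number from compound 3 to compound 4 (0.01 log units; within the scatter) and so leaves the read-out where it was. At this position, on an aromatic carbon para to a large group, methyl and methoxy cannot be told apart on this read-out, although methoxy brings one more heavy atom and a hydrogen-bond acceptor, and no measurement at hand explains this result.

Methyl and methoxy are only two small groups, so it remains open whether the same position would give a similar number with something quite different there, such as an amine, a carboxylic acid or a longer chain such as butoxy. It is also open whether the swap from methyl to methoxy would read the same way on a version of the shared core without the three methoxy groups on its fused ring system, since only the methoxy member of that pair is shown.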